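The source may hold more compounds than are shown below. What is called first, only, known or untested is meant among the compounds shown, and "the series" means these compounds.

Working notes on the series. In a functional assay on HL-60 cells (Homo sapiens) for cytotoxicity, read by MTT assay, with a stated time of 48 h (on this read-out lower numbers stand for stronger inhibition and higher numbers for weaker inhibition), compound 1 (`C=C1C(=O)O[C@@H](C)[C@@H]1c1ccc(OC)cc1`) gives 5560 nM and compound 2 (`C=C1C(=O)O[C@H](C)[C@@H]1c1ccc(C)cc1`) gives 5620 nM on the same read-out, so the two sit level within the scatter and no order can be read between them. Compound 3 (`C=C1C(=O)O[C@@H](C)[C@@H]1c1ccc(C)cc1`) still awaits measurement and is set against compound 2. The change is the two compounds have the same atoms and bonds and differ only in configuration as drawn: 1 of 2 stereo elements differ; a stereocentre at a saturated ring carbon is drawn R in compound 2 and S in compound 3 and nothing else: a stereocentre at a saturated ring carbon is drawn R in compound 2 and S in compound 3, and no group leaves or enters. Among the measured compounds shown here, the series holds no measured pair that differs in configuration alone, so the effect of such a change in this assay is unknown. The expectation therefore rests only on compound 2 at 5620 nM as the starting level: no direction is favoured, and no step beyond the scatter is expected. The estimated step is a 1.0-fold lower number from compound 2 to compound 3 (0.01 log units; within the scatter) as a working figure. For compound 3 the expected value is 5500 nM with an estimated range from 2200 nM to 14000 nM for now.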

Compound 3, half-maximal inhibitory concentration: 5010 nM
The estimate for compound 3 lay 1.1-fold (0.04 log units) above the measured number, within the range that was stated.
By their numbers in this assay, from the lowest: compounds 3, 1 and 2 (each within the scatter of the next).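

In this assay, among the compounds shown here, this is the first pair that differs in configuration alone, and it gives a 1.1-fold lower number from compound 2 to compound 3 (0.05 log units; within the scatter), so in this pair, with methyl on the aromatic carbon, the R and S drawings of the stereocentre at a saturated ring carbon cannot be told apart on this read-out. The second step adds a comparison in the same configuration as drawn: methyl in place of methoxy on an aromatic carbon gives a 1.1-fold lower number from compound 1 to compound 3 (0.05 log units; within the scatter), which also cannot be told apart from the scatter. The first step can be tied to that one stereocentre because no group leaves or enters: the fact that compounds 2 and 3 differ only in the configuration as drawn.

The compounds shown leave open whether the stereocentre stays equally silent when an amine, a carboxylic acid or a longer chain stands on the aromatic carbon in place of methyl or methoxy. For the compounds shown here, with only one pair for each change, they also leave open whether either result holds beyond these three compounds.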